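A Sulfur Side Chain Swaps Its Amide for an Ether

This account rests on a few compounds, and the source may have more. Where it says the series, first, only, none or still open, it means among the compounds named here.

Compound 1 `CC(C)c1n[nH]c2c(NCc3ccc(-c4ccccn4)cc3)nc(SCC(N)=O)nc12`: 192 nM
Compound 2 `CC(C)c1n[nH]c2c(NCc3ccc(-c4ccccn4)cc3)nc(S)nc12`: 2760 nM

Of the compounds shown here, two sharing one core have been measured in a functional assay on HT cells (Homo sapiens) for antiproliferative activity, read by fluorescence, with a stated time of 72 h; a higher number here means a weaker inhibitor of growth, a lower number a stronger inhibitor of growth. Compound 1 gives 192 nM, the lowest of the two numbers and therefore the stronger growth inhibitor of the pair. Compound 2 gives 2760 nM. Among the compounds with values here, the only step on record, a 14-fold higher number from compound 1 to compound 2 (1.16 log units; beyond the scatter), shows that taking the whole carbamoylmethyl off the sulfur costs a great deal of activity.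

Compound 3 `COCSc1nc(NCc2ccc(-c3ccccn3)cc2)c2[nH]nc(C(C)C)c2n1` is not yet measured. It keeps the chain on the sulfur but changes its end: methoxy in place of carbamoyl on a saturated chain carbon bound to a sulfur. The step from compound 1 to compound 2 bears on this, since it shows the group on the sulfur matters, but it removes the chain entirely, whereas compound 3 only trades carbamoyl for methoxy and so keeps a chain and one hydrogen-bond acceptor while losing the donor. Within the data shown here, a weakening is therefore expected in this assay, smaller than the one seen for compound 2 but likely beyond the scatter, as a 3.4-fold higher number from compound 1 to compound 3 (0.53 log units; beyond the scatter). Compound 3 is estimated at 650 nM, with a plausible range from 220 nM to 2200 nM.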

Compound 3, concentration for 50% growth inhibition: 340 nM
Compound 3: middle estimate off by 1.9-fold (0.28 log units), on the high side; low and high end bracket the measured number.
By their numbers in this assay, from the lowest: compounds 1 and 3 (each within the scatter of the next); then compound 2.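

Measured in this assay the swap of carbamoyl for methoxy gives a 1.8-fold higher number from compound 1 to compound 3 (0.25 log units; within the scatter) and so the two compounds cannot be told apart: at the end of this chain on the sulfur, the hydrogen-bond donor of carbamoyl can go without a change that this measurement can resolve. Set against hydrogen on the sulfur, methoxymethyl gives an 8.1-fold lower number from compound 2 to compound 3 (0.91 log units; beyond the scatter) and this shows that the amide is not needed to keep growth inhibition well apart from that of compound 2, since a chain ending in an ether does so too. Nothing measured here explains why the chain on the sulfur matters or why these two ends fall so close together.

Both chains shown still carry a hydrogen-bond acceptor, so the compounds leave open whether a plain ethyl group, with no oxygen at all, would serve as well as methoxymethyl. They also leave open how the number would respond to an amine or a carboxylic acid at the end of the chain, or to a longer chain such as methoxyethyl.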